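Swapping an Ethylphenyl for a Chlorobenzyl Group

The source may hold more compounds than are shown below. What is called first, only, known or untested is meant among the compounds shown, and "the series" means these compounds.

Measured compounds:
compound 1 `C=C(Br)C(=O)Nc1cccc(-c2cn3nc(-c4ccc(CC)cc4)sc3n2)c1` with 2200 nM
compound 2 `C=C(Br)C(=O)Nc1cccc(-c2cn3nc(Cc4ccccc4)sc3n2)c1` with 3000 nM

In a functional assay on L1210 cells (Mus musculus) for inhibition, read by cell counting, with a stated time of 2 days (on this read-out higher numbers stand for weaker inhibition and lower numbers for stronger inhibition), compound 1 gives 2200 nM. Compound 2 gives 3000 nM, and the step of a 1.4-fold higher number from compound 1 to compound 2 (0.13 log units; within the scatter) is within the scatter, so compound 1 and compound 2 stand at the same level. Compound 3 `C=C(Br)C(=O)Nc1cccc(-c2cn3nc(Cc4ccc(Cl)cc4)sc3n2)c1` is not yet measured; it differs from compound 1 by 4-chlorobenzyl in place of 4-ethylphenyl on an aromatic carbon. Among the compounds with values here, the only step that bears on this, a 1.4-fold higher number from compound 1 to compound 2 (0.13 log units; within the scatter), replaced the same group with a benzyl and changed little. A step of similar size, a 1.2-fold higher number from compound 1 to compound 3 (0.07 log units; within the scatter), is therefore expected. Compound 3 is estimated at 2600 nM, with a range from 1200 nM to 5500 nM.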

Compound 3, half-maximal inhibitory concentration: 2300 nM
Compound 3: the middle estimate sits 1.1-fold (0.05 log units) above what was measured, and the stated range covers the measured number.
By their numbers in this assay, from the lowest: compounds 1, 3 and 2 (each within the scatter of the next).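

In this assay there is a 1.0-fold higher number from compound 1 to compound 3 (0.02 log units; within the scatter) for 4-chlorobenzyl in place of 4-ethylphenyl and a 1.3-fold lower number from compound 2 to compound 3 (0.12 log units; within the scatter) for adding chloro to the benzyl group. At this position, then, all three aromatic groups stand at one level, and a chlorine on the benzyl group adds no measurable change. No data here explain why these groups read alike.

On these data alone, whether an amine, a carboxylic acid or a longer alkyl chain at this position would stay at that level remains open.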